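Swapping Methoxy for Cyclopropyl on Compound 2

The source may hold more compounds than are shown below. What is called first, only, known or untested is meant among the compounds shown, and "the series" means these compounds.

Three measured compounds share one core and differ in small groups. In an assay for antagonist activity at proteinase-activated receptor 4 (Homo sapiens), with stated times of 5 min, 50 s and 15 min, in the presence of a further agent that is not named here (on this read-out higher numbers stand for weaker inhibition and lower numbers for stronger inhibition), compound 2 `COc1nn2cc(-c3cc4ccccc4o3)nc2s1` gives 240 nM, the lowest number of the three. Compound 1 `COc1nn2cc(-c3cc4ccc(OCc5ccccc5)cc4o3)nc2s1` gives 1800 nM, and the step of a 7.5-fold lower number from compound 1 to compound 2 (0.88 log units; beyond the scatter) is modest but beyond the scatter. Compound 3 `COc1nn2cc(-c3cc4c(OC)cccc4o3)nc2s1` gives 350 nM, and the step of a 1.5-fold higher number from compound 2 to compound 3 (0.16 log units; within the scatter) lies within the scatter. Compound 4 `c1ccc2oc(-c3cn4nc(C5CC5)sc4n3)cc2c1` is not yet measured; it differs from compound 2 by cyclopropyl in place of methoxy on an aromatic carbon. Going by the values given here, neither measured step changes the carbon that this swap changes, so no measured step bears directly on it. The step of a 1.3-fold higher number from compound 2 to compound 4 (0.10 log units; within the scatter) in this assay is therefore expected to be small, in either direction. Compound 4 is estimated at 300 nM, with a range from 80 nM to 1200 nM.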

Compound 4, half-maximal inhibitory concentration: > 30000 nM
Compound 4: only a limit was reported; the forecaster's own chance of this, stated with the estimate: 5%; middle value at least 100-fold (2.00 log units) away from the limit.
By their numbers in this assay, from the lowest: compounds 2 and 3 (each within the scatter of the next); then compound 1. At a limit, above all of these: compound 4.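

Going by these compounds alone, the carbon next to the ring nitrogen and next to the ring sulfur is changed here for the first time, and this single swap of methoxy for cyclopropyl gives an at least 120-fold higher number from compound 2 to compound 4 (2.09 log units; beyond the scatter). Small groups at this carbon are therefore not interchangeable in this assay, a point the earlier steps, made at other places, could not show. The value of compound 4 is a limit: the limit of > 30000 nM in this assay, at which 1 of the 4 values shown sits.

The compounds shown leave open whether the oxygen of methoxy or the ring of cyclopropyl matters more here. As far as these compounds go, how an ethoxy group, a methyl group or an amine at this carbon would read also remains open.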